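Methoxymethyl gives way to fluoromethyl: compound 3 awaits measurement

The compounds below may be only part of what the source reports. "The series", "measured", "known", "first", "only" and "open" are said of these compounds alone.

Of the compounds shown here, two that share a core have been measured in a functional assay on HeLa cells (Homo sapiens) for cytotoxicity, read by WST assay, with a stated time of 48 h; on this read-out lower numbers stand for stronger inhibition and higher numbers for weaker inhibition. There, compound 1 `COC[C@H](C(C)C)C(c1ccc(O)c(OC)c1)c1ccc(O)c(OC)c1` gives 76000 nM and compound 2 `COC[C@H](C)[C@@H](C)C(c1ccc(O)c(OC)c1)c1ccc(O)c(OC)c1` gives 77000 nM. Compound 2 therefore stands level with compound 1, and the pair offers no ranking. The next compound is compound 3 `COc1cc(C(c2ccc(O)c(OC)c2)[C@H](CF)C(C)C)ccc1O`, which differs from compound 2 at a single place: 1-(fluoromethyl)-2-methylpropyl in place of 2-(methoxymethyl)-1-methylpropyl on a saturated chain carbon bound to two aromatic carbons. In words, 1-(fluoromethyl)-2-methylpropyl takes the place of 2-(methoxymethyl)-1-methylpropyl on a saturated chain carbon bound to two aromatic carbons. Going by the values given here, only one measured step bears on this change, a 1.0-fold higher number from compound 1 to compound 2 (0.01 log units; within the scatter). That step exchanged two methoxymethyl-bearing chains and left this assay unmoved, but neither of its compounds carries fluorine, so the data do not show directly what fluoromethyl will do. With compound 2 at 77000 nM as the starting point, no shift beyond the scatter is expected, and any drift is tentatively expected to be slight. The estimated step is a 1.2-fold lower number from compound 2 to compound 3 (0.07 log units; within the scatter). For compound 3 the expected value is 65000 nM, with an estimated range of 30000 nM to 130000 nM.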

Compound 3, half-maximal inhibitory concentration: 19000 nM
Estimate against measurement, compound 3: 3.4-fold (0.53 log units) above, and the stated range ends above it.
By their numbers in this assay, from the lowest: compound 3; then compounds 1 and 2 (each within the scatter of the next).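

In this assay, this position proves able to move the number: a 4.0-fold lower number from compound 1 to compound 3 (0.60 log units; beyond the scatter) when fluoro takes the place of methoxy on a saturated chain carbon, three bonds along the chain from two aromatic carbons. The change from 2-(methoxymethyl)-1-methylpropyl to 1-(fluoromethyl)-2-methylpropyl likewise gives a 4.1-fold lower number from compound 2 to compound 3 (0.61 log units; beyond the scatter) on a saturated chain carbon bound to two aromatic carbons, so the earlier silence of a 1.0-fold higher number from compound 1 to compound 2 (0.01 log units; within the scatter) in this assay held only for the two methoxymethyl-bearing chains and not for the position as a whole. No measurement is available that accounts for this shift.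

The compounds shown leave open whether the shift belongs to fluoro specifically or would also follow from another replacement of methoxy on that chain, such as hydroxy, an amine or chloro. They also leave open whether 2-(fluoromethyl)-1-methylpropyl would follow compound 3 in the way that the two methoxymethyl-bearing chains of compound 1 and compound 2 stand level with each other.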